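This account rests on a few compounds, and the source may have more. Where it says the series, first, only, none or still open, it means among the compounds named here.

Of the compounds shown here, three that share one core have been measured in a functional assay on A549 cells (Homo sapiens) for antiproliferative activity, read by MTT assay, with a stated time of 72 h; on this read-out higher numbers stand for weaker inhibition and lower numbers for stronger inhibition: compound 1 `COc1ccc(N2CCN(C(=S)SCc3ccc4nc(N)nc(N)c4c3)CC2)cc1` gives 1590 nM, compound 2 `Cc1ccccc1N1CCN(C(=S)SCc2ccc3nc(N)nc(N)c3c2)CC1` gives 3920 nM, and compound 3 `Cc1ccc(N2CCN(C(=S)SCc3ccc4nc(N)nc(N)c4c3)CC2)c(C)c1` gives 3000 nM. Compound 3 therefore sits within the scatter of both others, with a 1.3-fold lower number from compound 2 to compound 3 (0.12 log units; within the scatter) and a 1.9-fold higher number from compound 1 to compound 3 (0.28 log units; within the scatter). Only a 2.5-fold higher number from compound 1 to compound 2 (0.39 log units; beyond the scatter) goes beyond the scatter.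

Compound 4 `Nc1nc(N)c2cc(CSC(=S)N3CCN(c4ccc(Cl)cc4)CC3)ccc2n1` has not yet been measured. It has 4-chlorophenyl in place of 2,4-dimethylphenyl on an amine nitrogen in a ring. Among the compounds with values here, no measured step makes this exact swap, so the guidance is indirect. The closest comparison is compound 1, whose 4-methoxyphenyl also carries a single group on the ring and which gives 1590 nM. A small shift towards that value therefore seems reasonable, although the evidence is thin. The expected change is a 1.4-fold lower number from compound 3 to compound 4 (0.13 log units; within the scatter), which would not clearly exceed the scatter. For compound 4 the estimated value is 2200 nM, with an expected range from 1000 nM to 4800 nM.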

Compound 4, half-maximal inhibitory concentration: 5210 nM
Compound 4: the middle estimate sits 2.4-fold (0.37 log units) below what was measured; the whole stated range lies below it.
By their numbers in this assay, from the lowest: compounds 1, 3, 2 and 4 (each within the scatter of the next, the first and the last beyond it).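

In this assay, the new result shows that having a single group on this aromatic ring does not by itself bring the lower number of compound 1: chloro in place of methoxy gives a 3.3-fold higher number from compound 1 to compound 4 (0.52 log units; beyond the scatter). The identity of that one group therefore matters at this place, at least for this pair. In contrast, 4-chlorophenyl cannot be told apart from the two methyl-bearing rings, with a 1.7-fold higher number from compound 3 to compound 4 (0.24 log units; within the scatter) and a 1.3-fold higher number from compound 2 to compound 4 (0.12 log units; within the scatter).

The compounds shown leave open whether the lower number of compound 1 is special to methoxy or would also appear with an ethoxy or a dimethylamino group, and what a plain phenyl would give. No information is available on why chloro and methoxy differ here.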